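Dichloropyridyl ether step carried over to a second core

The source may hold more compounds than are shown below. What is called first, only, known or untested is meant among the compounds shown, and "the series" means these compounds.

The series rests on two cores. Compound 1 `O=C(O)c1ccc2noc(-c3ccc(Oc4ccccn4)cc3)c2c1` and compound 3 `O=C(O)c1ccc2noc(-c3cccc(Oc4ccccn4)c3)c2c1` are built from the same atoms joined differently; the difference between the two cores is not broken down here. In an assay for inhibition of inositol hexakisphosphate kinase 2 (Homo sapiens), read by colorimetric assay, coupled enzyme assay and malachite green, with a stated time of 120 min, in the presence of a further agent that is not named here (on this read-out lower numbers stand for stronger inhibition and higher numbers for weaker inhibition), compound 1 gives 1190 nM, and compound 3 gives 690 nM in the same read-out; the two values sit close together.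

Compound 2 `O=C(O)c1ccc2noc(-c3ccc(Oc4ncc(Cl)cc4Cl)cc3)c2c1` differs from compound 1 by 3,5-dichloropyridin-2-yl in place of pyridin-2-yl on an oxygen on an aromatic ring. In this assay compound 2 gives 650 nM, and the step is a 1.8-fold lower number from compound 1 to compound 2 (0.26 log units; within the scatter). Among the compounds with values here, this is the only measured instance of the change, so its size rests on a single pair.

Compound 4 `O=C(O)c1ccc2noc(-c3cccc(Oc4ncc(Cl)cc4Cl)c3)c2c1` has not yet been measured. It differs from compound 3 by 3,5-dichloropyridin-2-yl in place of pyridin-2-yl on an oxygen on an aromatic ring. The surroundings of the change read the same in both pairs, so it is the same change applied to the core of compound 3 instead of the core of compound 1.

Within the data shown here, for compound 4 the expectation is a step of about the same size as the one already seen, a 1.7-fold lower number from compound 3 to compound 4 (0.24 log units; within the scatter), because the measured precedent a 1.8-fold lower number from compound 1 to compound 2 (0.26 log units; within the scatter) is the only guide, and compound 3 starts from 690 nM. On that basis compound 4 is estimated at 400 nM in this assay, with a likely range from 180 nM to 900 nM, the width reflecting that the precedent itself is a single small step.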

Compound 4, half-maximal inhibitory concentration: 71 nM
Compound 4: middle estimate off by 5.6-fold (0.75 log units), on the high side; measured number below the stated range.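

The precedent did not carry over at its measured size. The change from pyridin-2-yl to 3,5-dichloropyridin-2-yl gives a 9.7-fold lower number from compound 3 to compound 4 (0.99 log units; beyond the scatter) in this assay, whereas the earlier pair gives a 1.8-fold lower number from compound 1 to compound 2 (0.26 log units; within the scatter), so only the new step stands clear of the usual variation between repeats, and the size of the step depends on the core it is made on: the same change on two cores in this assay, a 1.8-fold lower number (0.26 log units; within the scatter) from compound 1 to compound 2 and a 9.7-fold lower number (0.99 log units; beyond the scatter) from compound 3 to compound 4, 5.3-fold (0.72 log units) apart, beyond the scatter of two such steps. These two pairs show that a step measured on one core of this series is a poor guide to its size on the other, but they do not explain the difference, and they say nothing about whether other changes on the ether ring would differ between the cores in the same way.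

The compounds shown leave open whether both chlorines are needed for the larger step on the core of compound 3, or whether a pyridin-2-yl carrying a single chlorine, a trifluoromethyl or a nitrile would give a similar one. They also leave open whether the gap between the cores persists when the carboxylic acid is replaced by a tetrazole or a primary amide.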